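Hydrazinecarboxamide series: propyl in place of chlorothiophene

The source may report more compounds than this note shows. Statements on the series, on what has been measured and on what is new or still open speak of the compounds shown alone.

Measured so far:
compound 1 `Cn1ncc2c(-c3ccc(F)cc3)cc(NNC(=O)Nc3cc(Cl)cc(Cl)c3)nc21` — 39100 nM
compound 2 `Cc1nn(C)c2nc(NNC(=O)Nc3cc(Cl)nc(Cl)c3)cc(-c3ccc(Cl)s3)c12` — 42100 nM

In a functional assay on HCT-116 cells (Homo sapiens) for cytotoxicity, read by MTT assay, with a stated time of 48 h, in the presence of a further agent that is not named here (a lower number here means that less compound is needed, a higher number that more compound is needed for the effect), compound 2 gives 42100 nM, the higher of the two numbers, with compound 1 at 39100 nM; the gap lies within the scatter, so the two read alike. Compound 3 `CCCc1cc(NNC(=O)Nc2cc(Cl)nc(Cl)c2)nc2c1c(C)nn2C` is not yet measured. It differs from compound 2 by propyl in place of 5-chlorothiophen-2-yl on an aromatic carbon, on an aromatic carbon of the shared core. Going by the values given here, no step between measured compounds is available, so the effect of this change is unknown; the expectation is a small step, if any, upward. The expected step of a 1.4-fold higher number from compound 2 to compound 3 (0.15 log units; within the scatter) is estimated. Compound 3 is expected to give 60000 nM, in the range 20000 nM to 180000 nM.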

Compound 3, half-maximal effective concentration: 72200 nM
Beside the measured number, compound 3's estimate is 1.2-fold (0.08 log units) below it; the range from low to high includes it.
By their numbers in this assay, from the lowest: compounds 1, 2 and 3 (each within the scatter of the next).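

In this assay the exchange of 5-chlorothiophen-2-yl for propyl gives a 1.7-fold higher number from compound 2 to compound 3 (0.23 log units; within the scatter), so the two compounds read alike. At this place on the shared core, opposite the ring nitrogen, an open propyl chain with no ring reads like a five-membered aromatic ring carrying chlorine and sulfur. No available evidence bears on this result.

Going by these compounds, whether an amine, a carboxylic acid or a longer chain at this place would move the number beyond the scatter stays open. So does whether propyl reads the same on the core of compound 1.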